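The source may report more compounds than this note shows. Statements on the series, on what has been measured and on what is new or still open speak of the compounds shown alone.

Measured so far in an in vitro assay on HEK385-7 cells for displacement of a labelled ligand from prostaglandin D2 receptor 2 (Homo sapiens); on this read-out lower numbers stand for stronger inhibition and higher numbers for weaker inhibition:
- compound 1 `O=C(O)Cc1sc(C(c2ccccc2)c2ccccc2)nc1-c1cccc(F)c1`: 2.9 nM
- compound 2 `CS(=O)(=O)Nc1cccc(-c2nc(C(c3ccc(F)cc3)c3ccc(F)cc3)sc2CC(=O)O)c1`: 40 nM

Compound 2 stands highest of the two numbers; its nearest neighbour, compound 1, sits well lower, and the gap between the two lies beyond the scatter of this assay. Among the measured compounds shown here, no single-change step between measured compounds is available.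

Compound 3 `O=C(O)Cc1sc(C(c2ccc(F)cc2)c2ccc(F)cc2)nc1-c1ccnc(N2CCCC2)c1` is not yet measured. It differs from compound 2 by 2-(pyrrolidin-1-yl)pyridin-4-yl in place of 3-(methanesulfonamido)phenyl on an aromatic carbon.

For the measured compounds named here, with no comparable step on record, the step of a 2.7-fold lower number from compound 2 to compound 3 (0.43 log units; beyond the scatter) is an expectation only, set as a modest move downward that could still fall within the scatter. Compound 3 is estimated at 15 nM, with a range from 3 nM to 80 nM.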

Compound 3, half-maximal inhibitory concentration: 230 nM
Beside the measured number, compound 3's estimate is 15-fold (1.19 log units) below it; the measured number lies above the stated range.
By their numbers in this assay, from the lowest: compound 1; then compound 2; then compound 3.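

In this assay, 2-(pyrrolidin-1-yl)pyridin-4-yl in place of 3-(methanesulfonamido)phenyl on this aromatic carbon gives a 5.8-fold higher number from compound 2 to compound 3 (0.76 log units; beyond the scatter), so this position responds to the change beyond the scatter. The two groups hold the same heavy-atom count, so that count alone does not set the number here. No measured evidence accounts for the shift.

Still open, on these data alone, is whether the shift follows the pyridine ring or the pyrrolidine ring. A dimethylamino group in place of the pyrrolidine ring would help separate the two.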